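Three Compounds Resting at the Ceiling of a Cytotoxicity Assay

A few compounds are considered here, and "the series" means these few. Any claim that something is new, unique, unknown or untested is made for them only; others in the source may bear on it.

Compound 1 `O=[N+]([O-])c1cn2c(n1)OC[C@@H](OCc1ccc(-c3cncc(F)c3)s1)C2`, compound 2 `O=[N+]([O-])c1cn2c(n1)OC[C@@H](OCc1csc(-c3ccc(F)cc3)n1)C2` and compound 3 `Cn1c(CO[C@@H]2COc3nc([N+](=O)[O-])cn3C2)cnc1-c1ccc(C#N)cc1` share a common core and differ in the aromatic group carried on the side chain. In an ADME assay on Vero cells (Chlorocebus sabaeus) for cytotoxicity, with a stated time of 72 h (on this read-out higher numbers stand for weaker inhibition and lower numbers for stronger inhibition), compound 1 reaches only the limit of the assay, > 128000 nM. In this assay compound 2 likewise gives no number but a limit, > 128000 nM. Compound 3 also stops at a limit in this assay, > 128000 nM. Compound 3 therefore stands exactly where the other two stand: at the ceiling of the assay, which is where every value shown sits (the limit of > 128000 nM in this assay, at which 3 of the 3 values shown sit).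

Compound 4 `Cn1c(CO[C@@H]2COc3nc([N+](=O)[O-])cn3C2)cnc1-c1ccc(OC(F)(F)F)cc1` is compound 3 with trifluoromethoxy in place of cyano on an aromatic carbon. Among the measured compounds shown here, no measured step joins compound 3 to compound 4, and nothing among the three measured compounds points to a shift beyond the scatter in this assay; compound 4 is expected to remain at the limit as well. The estimate for compound 4 in this assay is 160000 nM, with a range from 60000 nM to 400000 nM. This estimate means an expected step that the limit leaves unreadable from compound 3 to compound 4.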

Compound 4, half-maximal inhibitory concentration: > 128000 nM
Compound 4 was reported as a limit (the forecaster's own chance of this, stated with the estimate: 85%); the middle value is on the limit's open side.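

Compound 3 and compound 4 both stop at a limit in this assay, so no step can be read between them: the limit of > 128000 nM in this assay, at which 4 of the 4 values shown sit. The compounds shown leave open where any of them would give an actual value in this assay, and whether trifluoromethoxy in place of cyano changes that value.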